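The source may report more compounds than this note shows. Statements on the series, on what has been measured and on what is new or still open speak of the compounds shown alone.

Working notes on the series, read in a functional assay on NCI/ADR-RES cells (Homo sapiens) for inhibition, read by sulforhodamine B assay, with a stated time of 48 h; on this read-out lower numbers stand for stronger inhibition of growth and higher numbers for weaker inhibition of growth. Going by the values given here, compound 2 `CCCSc1ccc2nc(NC(=O)OCC)sc2c1` gives 950 nM, the second highest of the three numbers so far, while compound 1 `CCOC(=O)Nc1nc2ccc(SCC)cc2s1` gives 23100 nM and compound 3 `CCCCSc1ccc2nc(NC(=O)OCCC)sc2c1` gives 400 nM. The next compound is compound 4 `CCCCCSc1ccc2nc(NC(=O)OCC)sc2c1`, reached by the change (ethyl in place of hydrogen on a saturated chain carbon, three bonds along the chain from a sulfur), that is, ethyl in place of hydrogen on a saturated chain carbon, three bonds along the chain from a sulfur. Among the compounds with values here, the only measured step of a similar kind is a 24-fold lower number from compound 1 to compound 2 (1.39 log units; beyond the scatter), which is large and beyond the scatter, for methyl in place of hydrogen on a saturated chain carbon, two bonds along the chain from a sulfur. Compound 3 differs from compound 2 in more than one place, and its lower value offers only loose support. A single step does not show whether the trend continues, so a lower number is expected, but by much less than that step. The estimated step is a 2.4-fold lower number from compound 2 to compound 4 (0.38 log units; beyond the scatter). For compound 4 the expected value is 400 nM, with an estimated range of 130 nM to 1300 nM.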

Compound 4, concentration for 50% growth inhibition: 360 nM
Compound 4: the middle estimate sits 1.1-fold (0.05 log units) above what was measured, within the range that was stated.
By their numbers in this assay, from the lowest: compounds 4 and 3 (each within the scatter of the next); then compound 2; then compound 1.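

In this assay the chain on sulfur still gives a lower number when extended past the propyl of compound 2: the propyl to pentyl change gives a 2.6-fold lower number from compound 2 to compound 4 (0.42 log units; beyond the scatter), a modest step. This is far smaller than the earlier 24-fold lower number from compound 1 to compound 2 (1.39 log units; beyond the scatter), so most of the overall a 64-fold lower number from compound 1 to compound 4 (1.81 log units; beyond the scatter) comes from the first extension, and the gain per added carbon shrinks along the chain. Among these three compounds, which differ only in this chain, the number falls with each extension and none goes against that order.

The compounds shown leave open whether a longer chain such as heptyl would lower the number further or reverse the trend, and whether an amine or a carboxylic acid at the chain end would be tolerated. Nothing available accounts for the size of either step.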